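A few compounds are considered here, and "the series" means these few. Any claim that something is new, unique, unknown or untested is made for them only; others in the source may bear on it.

Working notes on the series. Compound 1 `CC(C)C(c1ccc(-c2ccc3cccc(F)c3c2)[nH]c1=O)N1CCCCS1(=O)=O` is the starting point of this step. Going by the values given here, in an ADME assay on microsomes from liver (Mus musculus) for metabolic stability (a higher number here means that the compound lasts longer, a lower number that the compound disappears faster), compound 1 gives 0.0733 h, and this is the only actual number in hand for the series. Compound 2 `CCn1ncc2c(F)cc(-c3ccc(C(CC)(CC)c4nnc(C)[nH]4)c(=O)[nH]3)cc21` is the second member shown. In this assay compound 2 returns only a limit of the assay, > 3 h, so no number stands beside it. Thus the record of this assay consists of one number and one limit, (the limit of > 3 h in this assay, at which 1 of the 2 values shown sits), and compound 1 stands alone as the measured point.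

Compound 3 `CC(C)C(Nc1nccs1)c1ccc(-c2ccc3cccc(F)c3c2)[nH]c1=O` is not yet measured. Compared with compound 1 the change is a group of 6 heavy atoms (3 carbon, 2 nitrogen, 1 sulfur; one five-membered aromatic ring with 2 hetero atoms) in place of a group of 8 heavy atoms (4 carbon, 1 nitrogen, 2 oxygen, 1 sulfur; one six-membered non-aromatic ring with 2 hetero atoms), on a saturated chain carbon bound to an aromatic carbon and a saturated chain carbon. Among the compounds with values here, no step between two measured compounds is available to calibrate this change, so the expected step from compound 1 to compound 3 in this assay, a 2.0-fold higher number from compound 1 to compound 3 (0.31 log units; beyond the scatter), is set as a modest rise that may not clear the scatter. The estimate for compound 3 in this assay is 0.15 h, with a range from 0.04 h to 0.6 h.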

Compound 3, half-life: 0.0733 h
Estimate against measurement, compound 3: 2.0-fold (0.31 log units) above; the range from low to high includes it.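

In this assay the first step available at this position reads no change at the digits printed from compound 1 to compound 3 (within the scatter) and so gives the position its first calibration. On the saturated chain carbon bound to an aromatic carbon and a saturated chain carbon, the (1,3-thiazol-2-yl)amino group, with its five-membered aromatic ring and 1 hydrogen-bond donor, stands level with the six-membered non-aromatic ring, which has 0 hydrogen-bond donors. Nothing in hand accounts for this result.

From the compounds shown here alone, whether any group on this carbon moves the half-life beyond the scatter stays open, for instance a primary amine or a carboxylic acid. Compound 2 differs from compound 1 in more than one place and carries only a limit of the assay, so the steps involving it cannot be read.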